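Series notes: compound 2 to compound 3

A few compounds are considered here, and "the series" means these few. Any claim that something is new, unique, unknown or untested is made for them only; others in the source may bear on it.

Compound 2 `NC(=O)CCSC(=S)NCc1cccnc1` carries a carbamoyl group at the chain end, and in a functional assay on MDA-MB-468 cells (Homo sapiens) for cytotoxicity, read by resazurin assay, with a stated time of 72 h (on this read-out lower numbers stand for stronger inhibition and higher numbers for weaker inhibition), compound 2 gives 4630 nM. This is the lowest of the two numbers recorded; the nearest is compound 1 `N#CCCSC(=S)NCc1cccnc1`, which in this assay gives 9530 nM. Among the compounds with values here, the single measured step, a 2.1-fold lower number from compound 1 to compound 2 (0.31 log units; beyond the scatter), is the only comparison available so far.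

Compound 3 `O=C(CCSC(=S)NCc1cccnc1)NCc1ccccc1` differs from compound 2 by benzyl in place of hydrogen on an amide-type nitrogen. Within the data shown here, no measured step touches the amide nitrogen, so nothing recorded bears directly on this change; the step from compound 1 to compound 2 concerns the chain terminus, not the nitrogen substituent, and offers no guide to size or direction here. The expectation for compound 3 is therefore held close to compound 2, with a wide range, a shift of a 1.5-fold lower number from compound 2 to compound 3 (0.19 log units; within the scatter) being anticipated as a central guess. In this assay compound 3 is estimated at 3000 nM, with a range from 800 nM to 12000 nM.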

Compound 3, half-maximal inhibitory concentration: > 100000 nM
Compound 3: no number, only a limit; the forecaster's own chance of this, stated with the estimate: 5%; at least 33-fold (1.52 log units) between middle value and limit.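

The earlier step, a 2.1-fold lower number from compound 1 to compound 2 (0.31 log units; beyond the scatter), concerned only the chain end and was modest, so it gave no sign of how the amide-type nitrogen would respond. This position proves far more sensitive in this assay: benzyl in place of hydrogen on that nitrogen gives an at least 21-fold higher number from compound 2 to compound 3 (1.33 log units; beyond the scatter), a large step in the direction of weaker inhibition, and a single change here outweighs the one measured at the chain end. The entry for compound 3 is a limit of the assay and not a number: the limit of > 100000 nM in this assay, at which 1 of the 3 values shown sits.

The compounds shown leave open whether the change in read-out belongs to benzyl in particular or to any group replacing the amide hydrogen, and a methyl group on the same nitrogen would begin to separate those two readings. Also open, on these data alone, is whether a phenyl group, or a longer chain ending in the same six-membered aromatic ring, behaves like benzyl, and how a carboxylic acid at the chain end would compare with the carbamoyl of compound 2.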